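The compounds below may be only part of what the source reports. "The series", "measured", "known", "first", "only" and "open" are said of these compounds alone.

Measured so far: compound 1 `COc1nc(N)nc2c1c(-c1cccs1)cn2[C@@H]1O[C@H](CO)[C@@H](O)[C@H]1O`, compound 2 `Nc1nc2c(c(-c3cccs3)cn2[C@@H]2O[C@H](CO)[C@@H](O)[C@H]2O)c(=O)[nH]1` and compound 3 `COc1nc(N)nc2c1c(-c1ccoc1)cn2[C@@H]1O[C@H](CO)[C@@H](O)[C@H]1O`.

In a functional assay on K562 cells (Homo sapiens), read by MTT assay, with a stated time of 72 h (a higher number here means a weaker inhibitor, a lower number a stronger inhibitor), compound 1 gives > 20000 nM, which is a limit of the assay and not a number. In this assay compound 3 likewise gives only a limit, > 20000 nM. Compound 2 gives 16800 nM in this assay. The difference between the core of compound 1 and the core of compound 2 is not broken down here. The change from compound 1 to compound 3 is furan-3-yl in place of thiophen-2-yl on an aromatic carbon. Its step, a step that the two limits leave unreadable from compound 1 to compound 3, cannot be read because both values sit at the limit of > 20000 nM in this assay, at which 2 of the 3 values shown sit.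

Compound 4 `Nc1nc2c(c(-c3ccoc3)cn2[C@@H]2O[C@H](CO)[C@@H](O)[C@H]2O)c(=O)[nH]1` has not yet been measured. It carries the same change, (furan-3-yl in place of thiophen-2-yl on an aromatic carbon), made on the core of compound 2. The step from compound 2 to compound 4 is expected to be a 1.2-fold higher number from compound 2 to compound 4 (0.08 log units; within the scatter). Going by the values given here, this expectation rests on compound 2, whose value 16800 nM is the only number among the three measured compounds, so no large readable shift is anticipated. Compound 4 is therefore estimated at 20000 nM, with a likely range from 8000 nM to 50000 nM.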

Compound 4, half-maximal inhibitory concentration: 12500 nM
Compound 4: middle estimate off by 1.6-fold (0.20 log units), on the high side, within the range that was stated.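

Carried to a second core, furan-3-yl in place of thiophen-2-yl gives a 1.3-fold lower number from compound 2 to compound 4 (0.13 log units; within the scatter) in this assay, so on this core the measurement does not separate the two groups. Going by these compounds alone, the step from compound 1 to compound 3 cannot be read, because both values are limits of the assay and not numbers: the limit of > 20000 nM in this assay, at which 2 of the 4 values shown sit. The series therefore offers only one readable step, which cannot show whether the change behaves alike on both cores.

The compounds shown leave open whether a different group in the same place, such as an amine or a carboxylic acid, would shift the value beyond the scatter. They also leave open whether any such effect would carry from one core to the other.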